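The compounds below may be only part of what the source reports. "The series", "measured", "known", "first", "only" and "open" are said of these compounds alone.

Of the compounds shown here, three measured so far share one core. Compound 1 has the structure `Nc1ccccc1NC(=O)/C=C/c1ccc(CSc2ccc(Cl)cc2)cc1`, compound 2 the structure `Cc1cc(C)cc(SCc2ccc(/C=C/C(=O)Nc3ccccc3N)cc2)c1`, and compound 3 the structure `Cc1ccc(SCc2ccc(C(=O)Nc3ccccc3N)cc2)cc1`. In a functional assay on A-375 cells (Homo sapiens) for inhibition, read by CCK-8 assay, with a stated time of 72 h, tested at 8 uM (on this read-out higher numbers stand for more inhibition of growth at the one concentration tested and lower numbers for less inhibition of growth), compound 1 gives 48.2%. In this assay compound 2 gives 2.49%. In this assay compound 3 gives 67%, the highest of the three numbers; compound 1 sits nearest to it, and compound 2 furthest, both gaps lying beyond the scatter. Among the measured compounds shown here, only one step between measured compounds differs in a single place: a number 45.7 percentage points lower from compound 1 to compound 2 (beyond the scatter), a large drop brought about by 3,5-dimethylphenyl in place of 4-chlorophenyl on a sulfur.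

Compound 4, structure `CCc1ccc(SCc2ccc(C(=O)Nc3ccccc3N)cc2)cc1`, is the next one to be measured. It differs from compound 3 by methyl in place of hydrogen on a saturated chain carbon bound to an aromatic carbon. For the measured compounds named here, no measured step touches exactly this change; the one step known, a number 45.7 percentage points lower from compound 1 to compound 2 (beyond the scatter), swaps the whole aryl group on sulfur rather than adding one carbon. With nothing closer to lean on, a modest step is expected, possibly within the scatter. Compound 4 is therefore estimated at 58%, in the range 32% to 78%, which would mean an expected step of a number 9 percentage points lower from compound 3 to compound 4 (within the scatter).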

Compound 4, percent growth inhibition at one concentration: 71.1%
For compound 4 the middle estimate is 13.1 percentage points below the measured one; the range from low to high includes it.
By their numbers in this assay, from the lowest: compound 2; then compound 1; then compounds 3 and 4 (each within the scatter of the next).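

Moving from 4-methylphenyl to 4-ethylphenyl gives, in this assay, a small step (a number 4.1 percentage points higher from compound 3 to compound 4 (within the scatter)). This position therefore accepts one added carbon with no difference beyond the scatter. Among the compounds shown here, the only earlier step (a number 45.7 percentage points lower from compound 1 to compound 2 (beyond the scatter)) replaced the whole aryl group and could not show this, and no measurement here offers an explanation for the result.

From the compounds shown here alone, it remains open how much more this position accepts: whether a longer chain such as propyl, or an amine or a carboxylic acid in the same place, would preserve growth inhibition. Each compound is also represented by a reading at a single concentration, so any difference in potency between compound 3 and compound 4 remains unresolved.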